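Swapping a furan group on a weak cytotoxic compound

A few compounds are considered here, and "the series" means these few. Any claim that something is new, unique, unknown or untested is made for them only; others in the source may bear on it.

In a functional assay on MCF7 cells (Homo sapiens) for cytotoxicity, read by ELISA, with a stated time of 4 days (on this read-out higher numbers stand for weaker inhibition and lower numbers for stronger inhibition), compound 1 (`Cc1ccsc1-c1cc(-c2ccoc2)cc(-c2ccc(Cl)cc2)n1`) gives 20300 nM, the highest number of the three measured and so the weakest inhibition among them. Compound 2 (`Clc1ccc(-c2cc(-c3ccoc3)cc(-c3ccc(Cl)s3)n2)cc1`) gives 2600 nM, and compound 3 (`Clc1ccc(-c2cc(-c3ccoc3)cc(-c3ccccn3)n2)s1`) gives 3360 nM.

Compound 4 (`Cc1ccsc1-c1cc(-c2ccc(Cl)o2)cc(-c2ccc(Cl)cc2)n1`) has not yet been measured. It keeps the 3-methylthiophen-2-yl and 4-chlorophenyl groups of compound 1 but carries 5-chlorofuran-2-yl in place of furan-3-yl on an aromatic carbon, opposite the ring nitrogen: 5-chlorofuran-2-yl in place of furan-3-yl on an aromatic carbon.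

Among the compounds with values here, all three measured compounds carry furan-3-yl, so no measured step tests this change directly. The closest guide is a swap elsewhere on the molecule, 5-chlorothiophen-2-yl in place of 3-methylthiophen-2-yl, which gave a 7.8-fold lower number from compound 1 to compound 2 (0.89 log units; beyond the scatter), a modest step beyond the scatter. The other measured step, a 1.3-fold higher number from compound 2 to compound 3 (0.11 log units; within the scatter), lies within the scatter and concerns a different group, so it adds little.

On this indirect evidence, a step toward stronger inhibition is expected, probably smaller than the first one, and no change cannot be ruled out. The estimated step is a 2.3-fold lower number from compound 1 to compound 4 (0.35 log units; beyond the scatter). Compound 4 is expected at 9000 nM, with an estimated range from 2500 nM to 28000 nM.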

Compound 4, half-maximal inhibitory concentration: 15300 nM
Estimate against measurement, compound 4: 1.7-fold (0.23 log units) below; measured number inside the range.
By their numbers in this assay, from the lowest: compounds 2 and 3 (each within the scatter of the next); then compounds 4 and 1 (each within the scatter of the next).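

Within the data shown here, this step is the first direct reading of the position opposite the ring nitrogen. With the 3-methylthiophen-2-yl and 4-chlorophenyl groups held fixed, this assay shows a 1.3-fold lower number from compound 1 to compound 4 (0.12 log units; within the scatter) for 5-chlorofuran-2-yl in place of furan-3-yl, so this change leaves the two compounds indistinguishable, unlike the swap of the thiophene group, which gave a 7.8-fold lower number from compound 1 to compound 2 (0.89 log units; beyond the scatter). In compound 1, then, this position accepts a chlorine-bearing furan attached through a different ring carbon without a reading beyond the scatter, although a single pair cannot show how far that holds for other groups. The information available gives no explanation for this result.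

Because the change alters both the point of attachment and the chlorine at once, these compounds cannot separate the two, and either alteration alone might matter, with any separate effects possibly offsetting each other. Going by these compounds, it also remains open whether the same swap would behave alike alongside 5-chlorothiophen-2-yl, as in compound 2, and whether a quite different group at this position, such as an amine or a carboxylic acid, would move the number beyond the scatter.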